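The source may report more compounds than this note shows. Statements on the series, on what has been measured and on what is new or still open speak of the compounds shown alone.

Among the measured compounds shown here, compound 1 `CC(c1ccc(-c2ccccc2)c(F)c1)c1nnc2n1N=C(c1ccc(Cl)cc1Cl)CS2` holds the lower of the two numbers measured so far: in a functional assay on HepG2 cells (Homo sapiens) for inhibition, read by sulforhodamine B assay, with a stated time of 72 h (on this read-out higher numbers stand for weaker inhibition and lower numbers for stronger inhibition), compound 1 gives 8600 nM, while compound 2 `CC(c1ccc(-c2ccccc2)c(F)c1)c1n[nH]c(=S)n1N` gives 21400 nM, a gap beyond the usual scatter. Compound 3 `CC(c1ccc(-c2ccccc2)c(F)c1)c1nnc2n1N=C(c1ccc([N+](=O)[O-])cc1)CS2` is not yet measured; it differs from compound 1 by 4-nitrophenyl in place of 2,4-dichlorophenyl on a carbon with a double bond to nitrogen. For the measured compounds named here, no measured pair shows this exact change, so no measured step can guide the direction; the expected step is modest, a 1.3-fold higher number from compound 1 to compound 3 (0.11 log units; within the scatter), and may stay within the scatter. On that basis, compound 3 is estimated to give about 11000 nM in this assay, with a likely range from 3500 nM to 35000 nM.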

Compound 3, half-maximal inhibitory concentration: 4300 nM
Estimate against measurement, compound 3: 2.6-fold (0.41 log units) above; the range from low to high includes it.
By their numbers in this assay, from the lowest: compounds 3 and 1 (each within the scatter of the next); then compound 2.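

Replacing 2,4-dichlorophenyl with 4-nitrophenyl on the carbon with a double bond to nitrogen gives a 2.0-fold lower number from compound 1 to compound 3 (0.30 log units; within the scatter) in this assay. This position therefore holds two differently substituted phenyl rings without a change beyond the scatter, although this single pair cannot show how far that tolerance extends. Nothing measured here explains this outcome. The compounds shown leave open how a 4-aminophenyl ring, a 4-carboxyphenyl ring or a plain methyl group would read at this carbon. They also leave open whether this swap would read the same on a different core.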